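Fluoro for Methoxy on a Selenocyanate Carbamate

This account rests on a few compounds, and the source may have more. Where it says the series, first, only, none or still open, it means among the compounds named here.

Compound 1 `COc1ccc(OC(=O)Nc2ccc([Se]C#N)cc2)cc1` gives 41500 nM in a functional assay on CCRF-CEM cells (Homo sapiens) for cytotoxicity, read by MTT assay, with a stated time of 72 h (a lower number here means a stronger inhibitor of growth, a higher number a weaker inhibitor of growth), the larger of the two numbers shown, although its gap to compound 2 lies within the scatter. Compound 2 `O=C(Nc1ccc([Se][Se]c2ccc(NC(=O)OCc3ccccc3)cc2)cc1)OCc1ccccc1` gives 34600 nM in this assay, so the two values cannot be ordered. Compound 3 `N#C[Se]c1ccc(NC(=O)Oc2ccc(F)cc2)cc1` differs from compound 1 by fluoro in place of methoxy on an aromatic carbon. Going by the values given here, no step between measured compounds informs this exchange, so only a shift within the scatter, in either direction, is expected: a 1.2-fold lower number from compound 1 to compound 3 (0.06 log units; within the scatter). Compound 3 is therefore estimated at 36000 nM, with a range from 15000 nM to 90000 nM.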

Compound 3, concentration for total growth inhibition: 41900 nM
Compound 3: the middle estimate sits 1.2-fold (0.07 log units) below what was measured; measured number inside the range.
By their numbers in this assay, from the lowest: compounds 2, 1 and 3 (each within the scatter of the next).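

The exchange of methoxy for fluoro on this aromatic carbon, para to a large group, gives a 1.0-fold higher number from compound 1 to compound 3 (0.00 log units; within the scatter) in this assay. Going by these compounds alone, this is the first reading at this position, and it shows that the two groups cannot be told apart here, although the fluoro compound has one heavy atom fewer and no hydrogen-bond acceptor in this place. No measurement is available that would account for this result. Going by these compounds, whether an amine, a carboxylic acid or a longer chain at this position would shift the number stays open.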